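The source may report more compounds than this note shows. Statements on the series, on what has been measured and on what is new or still open speak of the compounds shown alone.

Measured compounds:
compound 1, `Cc1ccc(S(=O)(=O)NCc2ccc(CNC(=O)c3ccc(Cl)cc3)cc2)cc1`, 50% in a functional assay on the whole organism for inhibition, with Mus musculus as the target, with stated times of 30 min and 2 h, at a dose of 10 mg/kg by the intraperitoneal route; on this read-out lower numbers stand for less inhibition and higher numbers for more inhibition at the one dose given (going by the name of the read-out)
compound 2, `Cc1ccc(S(=O)(=O)NCc2ccc(CNC(=O)c3cccc(Cl)c3)cc2)cc1`, 57% in this assay

Among these two numbers compound 2 gives the higher one, yet the only measured step, a number 7 percentage points higher from compound 1 to compound 2 (within the scatter), lies within the scatter, so the two compounds cannot be ranked. Compound 3, `COc1ccccc1C(=O)NCc1ccc(CNS(=O)(=O)c2ccc(C)cc2)cc1`, is not yet measured. It differs from compound 2 in one place: 2-methoxyphenyl in place of 3-chlorophenyl on a carbonyl carbon. For the measured compounds named here, no measured step exchanges a chlorophenyl for a methoxyphenyl, so the one step that bears on it is a number 7 percentage points higher from compound 1 to compound 2 (within the scatter), which shows that moving a group on this ring left the read-out within the scatter. On that basis the expected step of a number 7 percentage points lower from compound 2 to compound 3 (within the scatter) is small and of no clear direction. Compound 3 is therefore estimated to give 50% in this assay, with a likely range from 30% to 70%.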

Compound 3, a percentage reported as inhibition, in the whole organism at one dose (the size of the read-out at that dose, not a potency): "not active" (no number reported)
No number was reported for compound 3; the estimate stays without a comparison.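

For the compounds shown here, compound 3 is reported as "not active" without a number, and no step from compound 2 to compound 3 can be read in this assay. No supporting data bear on this result. The compounds shown leave open which part of the exchange of 3-chlorophenyl for 2-methoxyphenyl matters for the read-out.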